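Ring swap at the five-membered core, compound 3 to compound 4

The source may hold more compounds than are shown below. What is called first, only, known or untested is meant among the compounds shown, and "the series" means these compounds.

Compound 1 `Cc1cc(NC(=O)Cn2nnc(-c3ccccn3)n2)n(C2CCCCC2)n1` in an assay on HEK293 cells for activation of Kir3.1/Kir3.2 (Homo sapiens), read by thallium flux (a lower number here means that less compound is needed, a higher number that more compound is needed for the effect), gives 14600 nM. Compound 2 `Cc1cc(NC(=O)Cn2nnc(-c3ccnc(F)c3)n2)n(C2CCCCC2)n1` gives 441 nM in this assay, the change from compound 1 being a 33-fold lower number from compound 1 to compound 2 (1.52 log units; beyond the scatter). Compound 3 `Cc1cc(NC(=O)Cn2nnc(-c3cccc(F)n3)n2)n(C2CCCCC2)n1` returns in this assay only a limit of the assay, > 3000 nM. That limit is the point at which (the limit of > 3000 nM in this assay, at which 1 of the 3 values shown sits). Against compound 2 the step is an at least 6.8-fold higher number from compound 2 to compound 3 (0.83 log units; beyond the scatter), and against compound 1 it is a step that the limit leaves unreadable from compound 1 to compound 3. Compound 3 therefore stands at the weak end of the three values shown, without a number of its own.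

Compound 4 `Cc1cc(NC(=O)Cn2nnc(-c3ccc(Cl)c(C)c3)n2)n(C2CCCCC2)n1` differs from compound 3 in one place: 4-chloro-3-methylphenyl in place of 6-fluoropyridin-2-yl on an aromatic carbon. The measured steps touching this position are a 33-fold lower number from compound 1 to compound 2 (1.52 log units; beyond the scatter) and an at least 6.8-fold higher number from compound 2 to compound 3 (0.83 log units; beyond the scatter); both show that the group on the five-membered aromatic ring with 4 nitrogen can move the read-out by a wide margin, and in both the group entering or leaving carries a ring nitrogen, which the group entering compound 4 lacks. For the measured compounds named here, no measured step removes the ring nitrogen, so the direction rests on that spread alone. Compound 4 is expected at 1200 nM. Its range is estimated to run from 250 nM to 6000 nM. This would mean an expected at least 2.5-fold lower number from compound 3 to compound 4 (0.39 log units; beyond the scatter).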

Compound 4, half-maximal effective concentration: 712 nM
Compound 4: the middle estimate sits 1.7-fold (0.23 log units) above what was measured; the range from low to high includes it.
By their numbers in this assay, from the lowest: compounds 2 and 4 (each within the scatter of the next); then compound 1.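

A six-membered aromatic ring of carbon only is accepted on the five-membered aromatic ring with 4 nitrogen: in this assay, 4-chloro-3-methylphenyl in place of 2-fluoropyridin-4-yl gives a 1.6-fold higher number from compound 2 to compound 4 (0.21 log units; within the scatter), so a ring nitrogen in this group is not required for a value on a par with compound 2. Set against the pyridin-2-yl group, the same change gives a 21-fold lower number from compound 1 to compound 4 (1.31 log units; beyond the scatter), which shows that a large drop in the number at this position can come from a group with neither ring nitrogen nor fluorine. Against the 6-fluoropyridin-2-yl group the change gives an at least 4.2-fold lower number from compound 3 to compound 4 (0.62 log units; beyond the scatter), a step that rests on a limit for compound 3 and not on a number: the limit of > 3000 nM in this assay, at which 1 of the 4 values shown sits.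

Going by these compounds, how far the result depends on the chloro, the methyl or both remains open, as does the read-out of an unsubstituted phenyl or of a phenyl carrying only one of the two. Also open, on these data alone, is how this position responds to a group bearing an amine or a carboxylic acid, or to a saturated ring such as piperidine in place of the aromatic ring.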